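From 4-Chloro-3-(trifluoromethyl)phenyl to 3-Chlorophenyl on a Shared Core

The source may report more compounds than this note shows. Statements on the series, on what has been measured and on what is new or still open speak of the compounds shown alone.

Of the compounds shown here, three with the same core have been measured in a functional assay on U-251 cells (Homo sapiens) for inhibition, read by sulforhodamine B assay, with a stated time of 48 h; a higher number here means a weaker inhibitor of growth, a lower number a stronger inhibitor of growth. Compound 1 `CN1CCN(CCCOc2cccc3nc(Nc4ccc(Cl)c(C(F)(F)F)c4)ccc23)CC1` gives 1490 nM, compound 2 `CC(C)c1ccc(Nc2ccc3c(OCCCN4CCN(C)CC4)cccc3n2)cc1` gives 3280 nM, and compound 3 `CN1CCN(CCCOc2cccc3nc(Nc4ccc(F)c(F)c4)ccc23)CC1` gives 2680 nM. Compound 1 stands clearly apart from only one of the others. The data show a 2.2-fold higher number from compound 1 to compound 2 (0.34 log units; beyond the scatter), a modest step, and a 1.8-fold higher number from compound 1 to compound 3 (0.25 log units; within the scatter), which does not separate the pair. The remaining pair is not separated either, with a 1.2-fold lower number from compound 2 to compound 3 (0.09 log units; within the scatter).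

Compound 4 `CN1CCN(CCCOc2cccc3nc(Nc4cccc(Cl)c4)ccc23)CC1` has not yet been measured. Its difference from compound 1 is 3-chlorophenyl in place of 4-chloro-3-(trifluoromethyl)phenyl on a nitrogen on an aromatic ring, and the change lies on a nitrogen on an aromatic ring. Within the data shown here, no measured compound carries 3-chlorophenyl, so the data do not isolate this group. The closest evidence is the two measured replacements of the group in compound 1. With compound 2 at 3280 nM and compound 3 at 2680 nM, a step of similar size is expected here, towards a higher number and near the edge of the scatter. The expected step in this assay is a 1.6-fold higher number from compound 1 to compound 4 (0.21 log units; within the scatter). For compound 4 the estimate is 2400 nM, with an expected range from 1300 nM to 4400 nM.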

Compound 4, concentration for 50% growth inhibition: 1890 nM
Compound 4: the middle estimate sits 1.3-fold (0.10 log units) above what was measured; measured number inside the range.
By their numbers in this assay, from the lowest: compounds 1, 4, 3 and 2 (each within the scatter of the next, the first and the last beyond it).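

In this assay, replacing the group on this nitrogen with 3-chlorophenyl, which has fewer heavy atoms and no trifluoromethyl, gives a 1.3-fold higher number from compound 1 to compound 4 (0.10 log units; within the scatter), so this pair is not separated and the loss of those atoms leaves no readable change in growth inhibition at this place. Compound 4 is not separated from the other two compounds either, with a 1.4-fold lower number from compound 3 to compound 4 (0.15 log units; within the scatter) and a 1.7-fold lower number from compound 2 to compound 4 (0.24 log units; within the scatter), so it falls within the scatter of all three measured compounds, even though compounds 1 and 2 are told apart by a 2.2-fold higher number from compound 1 to compound 2 (0.34 log units; beyond the scatter). Nothing measured here explains why these groups on the nitrogen give such similar numbers.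

As far as these compounds go, the four compounds span only a narrow band, so it remains open whether a phenyl ring carrying an amine or a carboxylic acid would give a step clearly beyond the scatter. The rest of the molecule is the same in all four compounds, which leaves open what a longer chain at that end would do, and whether the narrow band would hold on such a changed compound.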